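A few compounds are considered here, and "the series" means these few. Any claim that something is new, unique, unknown or untested is made for them only; others in the source may bear on it.

Going by the values given here, in a functional assay on SMMC-7721 cells (Homo sapiens) for inhibition, read by CCK-8 assay, with a stated time of 72 h, tested at 8 uM (on this read-out higher numbers stand for more inhibition of growth at the one concentration tested and lower numbers for less inhibition of growth), compound 2 (`COc1ccc(SCc2ccc(C(=O)Nc3ccccc3N)cc2)cc1`) gives 80.1%, the higher of the two numbers so far. Compound 1 (`Nc1ccccc1NC(=O)/C=C/c1ccc(CSc2cccc(F)c2)cc1`) gives 8.25%, lower by a gap beyond the scatter. Compound 3 (`CCc1ccc(SCc2ccc(C(=O)Nc3ccccc3N)cc2)cc1`) differs from compound 2 in one place: ethyl in place of methoxy on an aromatic carbon, para to a large group. Among the compounds with values here, no measured pair isolates this change, so the guide is weak. The expected step in this assay, a number 7.1 percentage points lower from compound 2 to compound 3 (within the scatter), is small and downward, probably not beyond the scatter. For compound 3 the estimated value is 73%, within a range of 50% to 90%.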

Compound 3, percent growth inhibition at one concentration: 82.9%
The estimate for compound 3 lay 9.9 percentage points below the measured number, and the stated range covers the measured number.
By their numbers in this assay, from the lowest: compound 1; then compounds 2 and 3 (each within the scatter of the next).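

In this assay, going by these compounds alone, ethyl in place of methoxy on an aromatic carbon, para to a large group, gives a number 2.8 percentage points higher from compound 2 to compound 3 (within the scatter), the first one-place step. This position therefore tolerates the loss of the methoxy oxygen in this pair, with growth inhibition at the one concentration tested staying within the scatter. Nothing measured on these compounds accounts for the result. Open, as far as these compounds go, is whether an amine, a carboxylic acid or a longer chain such as butyl on this aromatic carbon would keep this level of inhibition. Also open, from the compounds shown here alone, is whether ethyl and methoxy stay equivalent on another core.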